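Trimming an ethoxy to a methoxy on a thiazole amide

The compounds below may be only part of what the source reports. "The series", "measured", "known", "first", "only" and "open" are said of these compounds alone.

Compounds measured so far:
compound 1, `CCOc1ccc(-c2cnc(NC(=O)CCCCCCNC(=O)C(O)(O)C(F)(F)F)s2)cc1`, 4050 nM
compound 2, `O=C(CCCCCCNC(=O)C(O)(O)C(F)(F)F)Nc1cccc(Br)c1`, 3060 nM
compound 3, `O=C(CCCCCCCNC(=O)C(O)(O)C(F)(F)F)Nc1ccccc1`, 41700 nM

All three were tested in a functional assay on HCT-116 cells (Homo sapiens) for inhibition, read by colorimetric assay, with a stated time of 3 days; on this read-out higher numbers stand for weaker inhibition and lower numbers for stronger inhibition. Among the three numbers, compound 1 stands second highest. Its nearest neighbour is compound 2, whose number is lower but lies within the usual scatter, so the two cannot be told apart on this basis. The furthest is compound 3, whose number is higher by a margin that is beyond the scatter.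

The next compound is compound 4, `COc1ccc(-c2cnc(NC(=O)CCCCCCNC(=O)C(O)(O)C(F)(F)F)s2)cc1`. It differs from compound 1 in one place:

hydrogen in place of methyl on a saturated chain carbon bound to an oxygen on an aromatic ring

Within the data shown here, no pair of measured compounds shows this kind of change, so there is no direct guide to its size. Given how small the change is, the author expects no step beyond the scatter, with the estimated step being a 1.1-fold higher number from compound 1 to compound 4 (0.05 log units; within the scatter) in this assay. Compound 4 is accordingly expected to give about 4500 nM, within a range from 1800 nM to 11000 nM.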

Compound 4, half-maximal inhibitory concentration: 930 nM
The estimate for compound 4 lay 4.8-fold (0.68 log units) above the measured number, outside the stated range (below it).
By their numbers in this assay, from the lowest: compound 4; then compounds 2 and 1 (each within the scatter of the next); then compound 3.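

In this assay, among these compounds, the change from 4-ethoxyphenyl to 4-methoxyphenyl gives a 4.4-fold lower number from compound 1 to compound 4 (0.64 log units; beyond the scatter) and so supplies the first step here that can be read directly. The saturated chain carbon bound to an oxygen on an aromatic ring therefore proves sensitive: the loss of one methyl, a single carbon with no hydrogen-bond donor or acceptor involved, carries the number beyond the usual scatter. Nothing measured here explains the step, which stands as an observation without a known cause.

This single pair does not show whether the number would keep falling with a hydroxy group in place of the methoxy or rise again with a propoxy chain. On these data alone, whether the same change would give a similar step on another core also remains open.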